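Fluoro for Methyl: Cytotoxicity on Vero Cells

The source may report more compounds than this note shows. Statements on the series, on what has been measured and on what is new or still open speak of the compounds shown alone.

Measured so far:
Compound 1 `O=C1CSC(c2ccc([N+](=O)[O-])cc2)N1CCN1CCCCC1` gives 100%
Compound 2 `Cc1ccc(C2SCC(=O)N2CCN2CCCCC2)cc1` gives 100%

Within the data shown here, in an ADME assay on Vero cells (Chlorocebus sabaeus) for cytotoxicity, read by neutral red uptake, tested at 12.3 ug/mL (a higher number here means a weaker effect of the compound at the concentration tested, a lower number a stronger effect), compound 2 gives 100%, level with compound 1; the one measured step, methyl in place of nitro, no change at the digits printed from compound 1 to compound 2 (within the scatter), showed no change. Both measured compounds sit at the top of the scale. Compound 3 `O=C1CSC(c2ccc(F)cc2)N1CCN1CCCCC1` differs from compound 2 by fluoro in place of methyl on an aromatic carbon. Among the measured compounds shown here, no measured step covers fluoro in place of methyl, so the expectation rests only on the two flat values. The expected step of no change at the digits printed from compound 2 to compound 3 (within the scatter) is none beyond the scatter. Compound 3 is estimated at 100%, within 90% to 100%.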

Compound 3, a percentage reported as activity, at one concentration (the size of the read-out at that concentration, not a potency): 100%
Estimate against measurement, compound 3: no gap at the digits printed; the range from low to high includes it.
By their numbers in this assay, from the lowest: compounds 1, 2 and 3 (each within the scatter of the next).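

In this assay, the change from 4-methylphenyl to 4-fluorophenyl gives no change at the digits printed from compound 2 to compound 3 (within the scatter), and fluoro in place of nitro gives no change at the digits printed from compound 1 to compound 3 (within the scatter). This place on the aromatic ring, para to a large group, has now carried nitro, methyl and fluoro, and the three compounds read alike at the top of the scale. No measurement shown gives a reason for this flat result. Going by these compounds, whether an amine, a carboxylic acid or a longer chain at this same place would also read alike remains open.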